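Fluoro in place of methoxy on compound 2

A few compounds are considered here, and "the series" means these few. Any claim that something is new, unique, unknown or untested is made for them only; others in the source may bear on it.

Values so far in a functional assay on A549 cells (Homo sapiens) for antiproliferative activity, read by sulforhodamine B assay, with a stated time of 48 h (on this read-out higher numbers stand for weaker inhibition and lower numbers for stronger inhibition), for the series:
- compound 1 `COc1cccc(/C=C/C(=O)C(=Cc2cc(OC)c(OC)c(OC)c2)C(=O)/C=C/c2cccc(OC)c2OC)c1OC` gives 230 nM in this series
- compound 2 `COc1ccc(OC)c(/C=C/C(=O)C(=Cc2ccc(O)c(OC)c2)C(=O)/C=C/c2cc(OC)ccc2OC)c1` gives 190 nM in this series

Among the measured compounds shown here, compound 2 at 190 nM and compound 1 at 230 nM lie within the scatter of each other, so compound 2 stands level with the only other number available.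

Compound 3 `COc1ccc(OC)c(/C=C/C(=O)C(=Cc2ccc(O)c(F)c2)C(=O)/C=C/c2cc(OC)ccc2OC)c1` keeps compound 2 intact except for one change from 4-hydroxy-3-methoxyphenyl to 3-fluoro-4-hydroxyphenyl. This puts fluoro in place of methoxy on an aromatic carbon, ortho to a hydroxy group fluoro in place of methoxy on an aromatic carbon and meta to a large group.

For the measured compounds named here, no measured pair isolates this change. The expectation therefore starts from compound 2 at 190 nM and allows a wide margin. In this assay a small step toward weaker inhibition is expected, not clearly beyond the scatter. The estimate means a 1.5-fold higher number from compound 2 to compound 3 (0.17 log units; within the scatter) as the expected step. Compound 3 is expected at 280 nM with an estimated range from 100 nM to 800 nM in this read-out.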

Compound 3, half-maximal inhibitory concentration: 220 nM
Compound 3: middle estimate off by 1.3-fold (0.10 log units), on the high side; low and high end bracket the measured number.
By their numbers in this assay, from the lowest: compounds 2, 3 and 1 (each within the scatter of the next).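

In this assay, fluoro in place of methoxy on an aromatic carbon, ortho to a hydroxy group, gives a 1.2-fold higher number from compound 2 to compound 3 (0.06 log units; within the scatter). Among the compounds shown here, this is the first step that isolates one place, as compound 1 and compound 2 differ in more than one, and it shows that the two compounds stand level with fluoro or methoxy at this position. No supporting measurement bears on why the two groups read alike.

From the compounds shown here alone, whether this position stays level with other groups, such as an amine, a carboxylic acid or a longer chain such as butoxy, remains open. Also open, going by these compounds, is whether the same change would read alike on the 2,5-dimethoxyphenyl arms or with the neighbouring hydroxy group replaced by an amine.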